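The source may report more compounds than this note shows. Statements on the series, on what has been measured and on what is new or still open speak of the compounds shown alone.

Compound 1 `COc1ccccc1OC(C)(C)C1OCC(C/C=C\CCC(=O)O)C(c2cccnc2)O1`: in an assay for inhibition of prostacyclin synthase (Homo sapiens), using microsomes (a lower number here means a stronger inhibitor, a higher number a weaker inhibitor), compound 1 gives 51000 nM.
Compound 2 `CC(C)(Oc1ccccc1Br)C1OCC(C/C=C\CCC(=O)O)C(c2cccnc2)O1`: in this assay compound 2 gives 7000 nM.
Compound 3 `COc1ccc(OC(C)(C)C2OCC(C/C=C\CCC(=O)O)C(c3cccnc3)O2)c([N+](=O)[O-])c1`: in this assay compound 3 gives 23000 nM.

All three share the same core and differ only in the aromatic ring attached through an oxygen to a saturated carbon. Compound 3 stands in the middle of the three: its number is lower than that of compound 1, as shown by a 2.2-fold lower number from compound 1 to compound 3 (0.35 log units; beyond the scatter), yet higher than that of compound 2, as shown by a 3.3-fold higher number from compound 2 to compound 3 (0.52 log units; beyond the scatter).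

Compound 4 `CC(C)(Oc1ccc(F)cc1[N+](=O)[O-])C1OCC(C/C=C\CCC(=O)O)C(c2cccnc2)O1` is the next step from compound 3. The change is fluoro in place of methoxy on an aromatic carbon, that is, a methoxy group is swapped for a fluoro group on the aromatic ring while the nitro group stays in place.

Going by the values given here, only one measured step is of a similar kind: a 7.3-fold lower number from compound 1 to compound 2 (0.86 log units; beyond the scatter), where a halogen also replaced a methoxy group on an aromatic carbon, though on a ring without a nitro group and at a different spot. That step gave a modestly lower number. The two other steps rebuilt the whole ring pattern and speak less directly to this change. A modestly lower number, or at most a change near the scatter, is therefore expected in this assay.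

Compound 4 is expected to give 12000 nM, with a likely range from 4000 nM to 35000 nM. That estimate means an expected step of a 1.9-fold lower number from compound 3 to compound 4 (0.28 log units; within the scatter).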

Compound 4, half-maximal inhibitory concentration: 9000 nM
Compound 4: middle estimate off by 1.3-fold (0.12 log units), on the high side; the measured number falls inside the stated range.
By their numbers in this assay, from the lowest: compounds 2 and 4 (each within the scatter of the next); then compound 3; then compound 1.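

In this assay, going by these compounds alone, replacing methoxy with fluoro on the ring carbon meta to a nitro group, with the rest of the molecule unchanged, gives a 2.6-fold lower number from compound 3 to compound 4 (0.41 log units; beyond the scatter), so the group at this carbon does affect the number; no earlier step changed this position alone. Measured against the other two rings, the 4-fluoro-2-nitrophenyl ring gives a 5.7-fold lower number from compound 1 to compound 4 (0.75 log units; beyond the scatter), and a 1.3-fold higher number from compound 2 to compound 4 (0.11 log units; within the scatter), which places two differently substituted rings within the scatter of each other. Both single swaps of methoxy for a halogen, bromo from compound 1 to compound 2 and fluoro from compound 3 to compound 4, lower the number, and no compound shown goes against this, although two pairs at different ring positions make only a thin pattern.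

Nothing available here explains why the number falls at this position. On these data alone, it remains open whether chloro, an amine or a hydroxyl group at the same carbon would lower the number further, and whether fluoro would have a similar effect on a ring with no nitro group.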